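The source may report more compounds than this note shows. Statements on the series, on what has been measured and on what is new or still open speak of the compounds shown alone.

Measured so far:
compound 1, `CCCSc1nc(Cl)c2c(n1)N(CC1CCCCC1)C(C(=O)N1CCN(C)CC1)N2`: in a functional assay on A549 cells (Homo sapiens) for antiproliferative activity, read by MTT assay, with a stated time of 72 h (on this read-out higher numbers stand for weaker inhibition and lower numbers for stronger inhibition), compound 1 gives 13200 nM.
compound 2, `CCCSc1nc(Cl)c2c(n1)N(CCNC(=O)OC(C)(C)C)C(C(=O)N1CCN(C)CC1)N2`: in this assay compound 2 gives 12400 nM.

Compound 2 and compound 1 lie within the scatter of each other, so no order between them can be read. Compound 3, `CCCSc1nc(Cl)c2c(n1)N(Cc1ccco1)C(C(=O)N1CCN(C)CC1)N2`, carries furan-2-yl in place of ((tert-butoxycarbonyl)amino)methyl on a saturated chain carbon bound to a nitrogen on an aromatic ring in a ring. Within the data shown here, the only step that bears on this place is a 1.1-fold lower number from compound 1 to compound 2 (0.03 log units; within the scatter), where a different group at the same place left the number within the scatter. For compound 3 no step beyond the scatter is therefore expected in this assay, and the estimate is 12000 nM with a range of 5000 nM to 30000 nM. The expected step, a 1.0-fold lower number from compound 2 to compound 3 (0.01 log units; within the scatter), is taken to stay within the scatter.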

Compound 3, half-maximal inhibitory concentration: 13600 nM
Compound 3: middle estimate off by 1.1-fold (0.05 log units), on the low side; the range from low to high includes it.
By their numbers in this assay, from the lowest: compounds 2, 1 and 3 (each within the scatter of the next).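

In this assay furan-2-yl gives a 1.1-fold higher number from compound 2 to compound 3 (0.04 log units; within the scatter) and a 1.0-fold higher number from compound 1 to compound 3 (0.01 log units; within the scatter) at this place. A five-membered aromatic ring therefore joins cyclohexyl and ((tert-butoxycarbonyl)amino)methyl with no separation among the three, and the exchange for a group with 0 hydrogen-bond donors leaves the number within the scatter as well. No supporting evidence is available to explain this flat result.

Open, going by these compounds, is whether a free primary amine or a carboxylic acid at this place would move the number beyond the scatter. A longer chain carrying a phenyl ring also remains untested in the compounds shown here.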